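The source may report more compounds than this note shows. Statements on the series, on what has been measured and on what is new or still open speak of the compounds shown alone.

Compound 1 `N#CC1=C(N)Oc2c(c3nc4ccccc4nc3c3ccccc23)C12C(=O)N(Cc1cnnn1-c1ccc(Cl)cc1)c1ccccc12` gives a value in an ADME assay on HUVEC cells (Homo sapiens) for antiproliferative activity, read by MTT assay, with a stated time of 48 h (on this read-out higher numbers stand for weaker inhibition and lower numbers for stronger inhibition), that is a limit of the assay: > 50000 nM.
Compound 2 `N#CC1=C(N)Oc2c(c3nc4ccccc4nc3c3ccccc23)C12C(=O)N(Cc1cnnn1-c1ccc(N)cc1)c1ccccc12` gives a value that is likewise a limit: > 50000 nM.
Compound 3 `N#CC1=C(N)Oc2c(N)cc3nc4ccccc4nc3c2C12C(=O)N(Cc1cnnn1-c1cccc(Br)c1)c1ccccc12` also gives a value that is a limit: > 50000 nM.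

The only pair among these that differs in one place is compound 1 and compound 2, and the step between them is a step that the two limits leave unreadable from compound 1 to compound 2, so it tells nothing about size. Compound 3 stands where every measured value sits, at the limit of > 50000 nM in this assay, at which 3 of the 3 values shown sit, with no number to mark it off from the others.

Compound 4 `CCOc1ccccc1-n1nncc1CN1C(=O)C2(C(C#N)=C(N)Oc3c(N)cc4nc5ccccc5nc4c32)c2ccccc21` is reached from compound 3 by a single change: 2-ethoxyphenyl in place of 3-bromophenyl on an aromatic nitrogen. Among the compounds with values here, no measured step touches this aromatic nitrogen, and the one measured step is unreadable, so nothing in the data points to a step in either direction beyond the scatter. The expectation is therefore that compound 4 stays at the limit, the step from compound 3 to compound 4 being a number no higher from compound 3 to compound 4 (the limit leaves the size open). Compound 4 is expected to give 50000 nM, within 20000 nM to 50000 nM.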

Compound 4, half-maximal inhibitory concentration: > 50000 nM
Compound 4 ended at the assay's limit (the forecaster's own chance of this, stated with the estimate: 85%); the middle value sits exactly at the limit.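

No new step can be read between compound 3 and compound 4, since both results in this assay are limits of the assay and not numbers: the limit of > 50000 nM in this assay, at which 4 of the 4 values shown sit.

The compounds shown leave open how strongly any of them acts, and whether any change to these structures would give a readable number.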